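Oxazole in Place of Trifluoromethylphenyl on the Shared Core

The source may report more compounds than this note shows. Statements on the series, on what has been measured and on what is new or still open speak of the compounds shown alone.

Compound 1 `O=C(NC(=S)N1CCc2c(OCCCCCOc3ccc(Cl)cc3)cccc21)c1ccc(C(F)(F)F)cc1` carries a 4-(trifluoromethyl)phenyl group on the carbonyl carbon of its acylthiourea. In an ADME assay on Huh-7 cells (Homo sapiens) for cytotoxicity (on this read-out lower numbers stand for higher toxicity in this test and higher numbers for lower toxicity in this test), compound 1 gives 32700 nM, the lowest of the two numbers recorded so far. Compound 2 `COc1ccc(C(=O)NC(=S)N2CCc3c(OCCCCCOc4ccc(Cl)cc4)cccc32)cc1`, which differs only by a methoxy in place of trifluoromethyl on an aromatic carbon, gives 34400 nM, and the step is a 1.1-fold higher number from compound 1 to compound 2 (0.02 log units; within the scatter).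

Compound 3 `O=C(NC(=S)N1CCc2c(OCCCCCOc3ccc(Cl)cc3)cccc21)c1ccno1` is not yet measured. Its difference from compound 1 is 1,2-oxazol-5-yl in place of 4-(trifluoromethyl)phenyl on a carbonyl carbon. For the measured compounds named here, the only measured step, from compound 1 to compound 2, changed a substituent on that phenyl ring and left the ring itself in place, so it bears on the new change only loosely; it showed no movement beyond the scatter. Compound 3 is therefore expected to sit near the two measured values, with a step of about a 1.1-fold higher number from compound 1 to compound 3 (0.03 log units; within the scatter) and an estimate of 35000 nM spanning 15000 nM to 80000 nM.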

Compound 3, half-maximal cytotoxic concentration: 37100 nM
For compound 3 the middle estimate is 1.1-fold (0.03 log units) below the measured one; the measured number falls inside the stated range.
By their numbers in this assay, from the lowest: compounds 1, 2 and 3 (each within the scatter of the next).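

The replacement gives a 1.1-fold higher number from compound 1 to compound 3 (0.05 log units; within the scatter) and, set against the 4-methoxyphenyl group, a 1.1-fold higher number from compound 2 to compound 3 (0.03 log units; within the scatter) in this assay at this position. The earlier step changed only a substituent on the phenyl ring, whereas here a six-membered aromatic ring of carbon only gives way to a five-membered aromatic ring with 2 hetero atoms, and the read-out stays within the scatter. No measurement at hand bears on why this exchange leaves the number in place.

All three compounds carry an aromatic ring on this carbonyl carbon, which leaves open whether an aliphatic amine or a carboxylic acid in the group there would give a number outside the scatter. The rest of the shared core is the same throughout, and a longer chain in it remains untested in the compounds shown here.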